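The source may hold more compounds than are shown below. What is called first, only, known or untested is meant among the compounds shown, and "the series" means these compounds.

Compound 1 `OC[C@H]1O[C@@H](n2cnc3c(NCc4cccc(F)c4)ncnc32)[C@H](O)[C@@H]1O`: > 166000 nM (limit)
Compound 2 `Cc1cccc(CNc2ncnc3c2ncn3[C@@H]2O[C@H](CO)[C@@H](O)[C@H]2O)c1`: > 166000 nM (limit)

Both entries come from a functional assay on G-361 cells (Homo sapiens) for antiproliferative activity, with a stated time of 72 h (a lower number here means a stronger inhibitor, a higher number a weaker inhibitor), and neither is a number. In that assay compound 1 gives > 166000 nM, which is a limit. Compound 2 gives > 166000 nM, which is also a limit. Compound 2 therefore has no measured potency and stands at the limit of > 166000 nM in this assay, at which 2 of the 2 values shown sit, together with compound 1.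

The next compound is compound 3 `OC[C@H]1O[C@@H](n2cnc3c(NCc4ccc(Cl)c(Cl)c4)ncnc32)[C@H](O)[C@@H]1O`, which carries 3,4-dichlorophenyl in place of 3-methylphenyl on a saturated chain carbon bound to a nitrogen on an aromatic ring.

Among the measured compounds shown here, only one measured step bears on this change, and it concerns a different substituent swap: a step that the two limits leave unreadable from compound 1 to compound 2. It supplies no size to carry forward, so no size or firm direction can be derived for this assay. The working expectation is that compound 3 stays close to the same limit, and any readable number would have to lie on the stronger side.

The estimated step is an at least 1.3-fold lower number from compound 2 to compound 3 (0.14 log units; that floor lies within the scatter).

For compound 3 the expected value is 120000 nM, with an estimated range of 30000 nM to 200000 nM.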

Compound 3, half-maximal inhibitory concentration: 145000 nM
Estimate against measurement, compound 3: 1.2-fold (0.08 log units) below; measured number inside the range.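

In this assay, among the compounds shown here, compound 3 gives 145000 nM, the first real number in this set, so a substituted benzyl group at this place, a saturated chain carbon bound to a nitrogen on an aromatic ring, can give a value inside the range of the assay. Placing 3,4-dichlorophenyl where 3-methylphenyl stood gives an at least 1.1-fold lower number from compound 2 to compound 3 (0.05 log units; that floor lies within the scatter), and placing it where 3-fluorophenyl stood gives an at least 1.1-fold lower number from compound 1 to compound 3 (0.05 log units; that floor lies within the scatter). Both floors lie within the scatter, so compound 3 cannot yet be ranked ahead of compound 1 or compound 2, which remain limits and not numbers: the limit of > 166000 nM in this assay, at which 2 of the 3 values shown sit.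

As far as these compounds go, how far compound 1 and compound 2 lie past that limit stays open, so the true size of either step is unknown, and the step between those two cannot be read. Also open, from the compounds shown here alone, is what an amine or a carboxylic acid on the phenyl ring, or a longer chain in place of the benzyl group, would do to the number in this assay.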